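The source may hold more compounds than are shown below. What is called first, only, known or untested is meant among the compounds shown, and "the series" means these compounds.

Compound 1 `CSc1ccc(C)cc1NCC1=NCCN1` gives 0.417 nM in a functional assay for agonist activity at Alpha-1B adrenergic receptor (Homo sapiens); a higher number here means that more compound is needed for the effect, a lower number that less compound is needed.
Compound 2 `Cc1ccc(S(C)(=O)=O)c(NCC2=NCCN2)c1` gives 141 nM in this assay.

Among the compounds with values here, of these two numbers, compound 2 holds the higher one; its nearest neighbour is compound 1, and the gap between them, a 340-fold higher number from compound 1 to compound 2 (2.53 log units; beyond the scatter), is the only measured step in this small set. That step arises from the methylsulfonyl in place of methylsulfanyl on an aromatic carbon, and it is large.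

Compound 3 `CS(=O)(=O)c1ccc(C(F)(F)F)cc1NCC1=NCCN1` has not yet been measured in this assay. It differs from compound 2 in one place: trifluoromethyl in place of methyl on an aromatic carbon. This change leaves the methylsulfonyl group of compound 2 in place and exchanges a single carbon for a trifluoromethyl para to that group, meta to a group of 7 heavy atoms.

Within the data shown here, no measured step bears on a methyl-to-trifluoromethyl exchange here; the one step in hand concerns a different group. The account therefore rests on the value of compound 2 alone and allows a wide band. Compound 3 is expected to give about 100 nM, within 20 nM to 600 nM, a step of a 1.4-fold lower number from compound 2 to compound 3 (0.15 log units; within the scatter) that is expected to stay near the scatter.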

Compound 3, half-maximal effective concentration: < 100000 nM
Compound 3: only a limit was reported (the forecaster's own chance of this, stated with the estimate: 5%); the middle value is on the limit's open side.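

Compound 3 gives < 100000 nM in this assay, which is a limit of the assay and not a number. The step between compound 2 and compound 3 cannot be read. The compounds shown leave open how far, and in which direction, trifluoromethyl in place of methyl on an aromatic carbon moves the number in this assay.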